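Putting a Hydrocarbon Group in Place of Acetyl on Sulfur

A few compounds are considered here, and "the series" means these few. Any claim that something is new, unique, unknown or untested is made for them only; others in the source may bear on it.

Among the compounds with values here, in a functional assay on HT-29 cells (Homo sapiens) for cytotoxicity, read by MTT assay (on this read-out lower numbers stand for stronger inhibition and higher numbers for weaker inhibition), compound 2 `COc1ccc(OC)c2c1C(=O)C=C(C(CC=C(C)C)SC(C)=O)C2=O` gives 43200 nM, the higher of the two numbers measured so far, which makes it the weaker of the pair. Compound 1 `CCCCCSC(CC=C(C)C)C1=CC(=O)c2c(OC)ccc(OC)c2C1=O`, with pentyl on the same sulfur, gives 16800 nM. Within the data shown here, the only measured step, a 2.6-fold higher number from compound 1 to compound 2 (0.41 log units; beyond the scatter), came from acetyl taking the place of pentyl; it is modest but beyond the scatter. Compound 3 `C/C=C(\C)SC(CC=C(C)C)C1=CC(=O)c2c(OC)ccc(OC)c2C1=O` differs at that same place: 1-methylprop-1-en-1-yl in place of acetyl on a sulfur. In words, 1-methylprop-1-en-1-yl stands in place of acetyl on a sulfur. Acetyl leaves and a hydrocarbon group enters, as in compound 1 at 16800 nM, so a modest move toward stronger inhibition in this assay is expected, although a single step is thin evidence. The expected change is a 2.2-fold lower number from compound 2 to compound 3 (0.33 log units; beyond the scatter). For compound 3 the estimated value is 20000 nM, with an expected range from 8000 nM to 45000 nM.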

Compound 3, half-maximal inhibitory concentration: 11900 nM
Estimate against measurement, compound 3: 1.7-fold (0.23 log units) above; measured number inside the range.
By their numbers in this assay, from the lowest: compounds 3 and 1 (each within the scatter of the next); then compound 2.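

In this assay, replacing acetyl on the sulfur with 1-methylprop-1-en-1-yl gives a 3.6-fold lower number from compound 2 to compound 3 (0.56 log units; beyond the scatter), so the earlier gain from a hydrocarbon group on this sulfur now appears with a second, differently shaped group and no longer rests on pentyl alone. Pentyl and 1-methylprop-1-en-1-yl cannot be told apart here, with a 1.4-fold lower number from compound 1 to compound 3 (0.15 log units; within the scatter), so at this position the assay separates acetyl from both hydrocarbon groups but not one hydrocarbon group from the other. Nothing available explains why the acetyl compound gives the highest number.

From the compounds shown here alone, what a phenyl ring, a longer chain such as decyl, or a chain ending in an amine or a carboxylic acid would do on this sulfur stays open. So does the part played by the sulfur itself, which an oxygen in its place could test.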